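The compounds below may be only part of what the source reports. "The series", "measured", "known", "first", "only" and "open" are said of these compounds alone.

Of the compounds shown here, three of a shared core have been measured so far in a functional assay, read by spectrophotometry, with a stated time of 1 h; a higher number here means a weaker inhibitor, a lower number a stronger inhibitor. Compound 1 `O=c1[nH]c2ccccc2cc1/C=N/O` gives 2010000 nM. Compound 2 `CCCC/N=C/c1cc2cc(C)ccc2[nH]c1=O` gives 3560000 nM. Compound 3 `N/N=C/c1cc2ccccc2[nH]c1=O` gives 365000 nM, which is the lowest of the three numbers, and its nearest neighbour among them is compound 1. Going by the values given here, the one measured step that changes the group on the double-bonded nitrogen is a 5.5-fold lower number from compound 1 to compound 3 (0.74 log units; beyond the scatter), a modest but real shift. Compound 4 `CCCC/N=C/c1cc2ccccc2[nH]c1=O` is not yet measured; it carries butyl in place of amino on a double-bonded nitrogen. Among the compounds with values here, no measured step covers this exact exchange. The step to compound 3 shows that this position moves the number beyond the scatter, and compound 2, which carries the same butyl group on a core that differs only in an added methyl, shows a number near the high end of what has been seen. Compound 4 is therefore expected to give a higher number than compound 3, with a 6.8-fold higher number from compound 3 to compound 4 (0.84 log units; beyond the scatter). The estimate for compound 4 is 2500000 nM, within the range 700000 nM to 9000000 nM.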

Compound 4, half-maximal inhibitory concentration: 7680000 nM
For compound 4 the middle estimate is 3.1-fold (0.49 log units) below the measured one; measured number inside the range.
By their numbers in this assay, from the lowest: compound 3; then compounds 1 and 2 (each within the scatter of the next); then compound 4.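

In this assay, the group on the double-bonded nitrogen proves able to move the number by far more than the earlier step suggested: butyl in place of amino gives a 21-fold higher number from compound 3 to compound 4 (1.32 log units; beyond the scatter), a large step on an unchanged core. Butyl in place of hydroxy gives a 3.8-fold higher number from compound 1 to compound 4 (0.58 log units; beyond the scatter), so among the three groups seen on this nitrogen, amino gives the lowest number and butyl the highest, with hydroxy in the middle. The core itself also counts, since hydrogen in place of methyl on an aromatic carbon, with butyl kept, gives a 2.2-fold higher number from compound 2 to compound 4 (0.33 log units; beyond the scatter). No measurement shown explains why these groups differ. Still open, as far as these compounds go, are how an ethyl chain or a phenyl ring would read on this nitrogen, and whether the methyl step would hold with amino or hydroxy there.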